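Acyl extension on the terminal sugar of compound 1

This account rests on a few compounds, and the source may have more. Where it says the series, first, only, none or still open, it means among the compounds named here.

Compound 1 `CCCCCCCCO[C@@H]1O[C@@H](C)[C@H](OC(=O)CCCCC)[C@@H](O[C@@H]2O[C@@H](C)[C@H](OC(C)=O)[C@@H](OC(C)=O)[C@H]2OC(C)=O)[C@H]1O` gives 15000 nM in a functional assay on NCI-H460 cells (Homo sapiens) for antiproliferative activity, read by MTT assay, with a stated time of 48 h (a higher number here means a weaker inhibitor, a lower number a stronger inhibitor), the lowest of the three numbers measured. Compound 2 `CCCCCCCCCCCCO[C@@H]1O[C@@H](C)[C@H](O[C@@H]2O[C@@H](C)[C@H](OC(C)=O)[C@@H](O[C@@H]3O[C@@H](C)[C@H](OC(C)=O)[C@@H](O)[C@H]3OC(C)=O)[C@H]2O)[C@@H](O)[C@H]1O` gives 91000 nM and compound 3 `CCCCCCCCO[C@@H]1O[C@@H](C)[C@H](OC(=O)CCCCC)[C@@H](O[C@@H]2O[C@@H](C)[C@H](O)[C@@H](OC(C)=O)[C@H]2OC(C)=O)[C@H]1O` gives 151000 nM; both gaps from compound 1 lie beyond the scatter, so compound 1 is the strongest inhibitor of the set. Among the measured compounds shown here, the only single-point step, a 10-fold higher number from compound 1 to compound 3 (1.00 log units; beyond the scatter), shows a substantial loss on removing an acetyl. Compound 4 `CCCCCCCCO[C@@H]1O[C@@H](C)[C@H](OC(=O)CCCCC)[C@@H](O[C@@H]2O[C@@H](C)[C@H](OC(C)=O)[C@@H](OC(=O)CC(C)C)[C@H]2OC(C)=O)[C@H]1O` differs from compound 1 by isopropyl in place of hydrogen on a saturated chain carbon bound to a carbonyl carbon. For the measured compounds named here, no measured step covers an extension of this kind; because a 10-fold higher number from compound 1 to compound 3 (1.00 log units; beyond the scatter) turned on removing an acyl while compound 4 keeps one, a loss of that size is not expected. For compound 4 a shift near the scatter is expected, a 1.5-fold lower number from compound 1 to compound 4 (0.18 log units; within the scatter). Compound 4 is estimated at 10000 nM, ranging from 3000 nM to 40000 nM.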

Compound 4, half-maximal inhibitory concentration: 79000 nM
Compound 4: the middle estimate sits 7.9-fold (0.90 log units) below what was measured, and the stated range ends below it.
By their numbers in this assay, from the lowest: compound 1; then compounds 4, 2 and 3 (each within the scatter of the next).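

Going from acetyl to isobutylcarbonyl costs activity in this assay, a 5.3-fold higher number from compound 1 to compound 4 (0.72 log units; beyond the scatter), so at this oxygen, keeping an acyl group does not by itself hold the value of compound 1. The earlier step showed only the loss of a different acetyl on the terminal sugar; this one shows that enlarging an acyl group also weakens the series. No data on hand account for this loss.

Open, going by these compounds, is whether a propionyl or a straight butanoyl group at this oxygen would behave in the same way. Also open, on these data alone, is whether the same isopropyl extension on the other acetyl groups gives a comparable step.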